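The compounds below may be only part of what the source reports. "The series", "measured", "known", "first", "only" and "open" are said of these compounds alone.

Compound 3 `CCc1cccc(C)c1-n1nncc1CN1C(=O)C2(C(C#N)=C(N)Oc3c(N)cc4nc5ccccc5nc4c32)c2ccccc21` stands at the upper edge of what an ADME assay on L02 cells (Homo sapiens) for antiproliferative activity, read by MTT assay, with a stated time of 48 h (on this read-out lower numbers stand for stronger inhibition and higher numbers for weaker inhibition), can resolve. In this assay compound 3 gives a limit rather than a number, > 50000 nM. Compound 2 `COc1ccc(-n2nncc2CN2C(=O)C3(C(C#N)=C(N)Oc4c(N)cc5nc6ccccc6nc5c43)c3ccccc32)cc1` likewise gives only a limit in this assay, > 50000 nM. Compound 1 `N#CC1=C(N)Oc2c(N)cc3nc4ccccc4nc3c2C12C(=O)N(Cc1cnnn1-c1cccc(C(F)(F)F)c1)c1ccccc12` gives a number in this assay, 38100 nM. The step of an at least 1.3-fold higher number from compound 1 to compound 2 (0.11 log units; that floor lies within the scatter) and the step of an at least 1.3-fold higher number from compound 1 to compound 3 (0.11 log units; that floor lies within the scatter) are both floored by the limit, and the step that the two limits leave unreadable from compound 2 to compound 3 cannot be read at all because of the limit of > 50000 nM in this assay, at which 2 of the 3 values shown sit. Compound 4 `Cc1ccc(C)c(-n2nncc2CN2C(=O)C3(C(C#N)=C(N)Oc4c(N)cc5nc6ccccc6nc5c43)c3ccccc32)c1` differs from compound 3 by 2,5-dimethylphenyl in place of 2-ethyl-6-methylphenyl on an aromatic nitrogen. All three measured steps change the aryl group on that same aromatic nitrogen, and none of them shows a readable change in this assay. The step expected in this assay is therefore a number no higher from compound 3 to compound 4 (the limit leaves the size open). Compound 4 is expected most likely to return a limit again. Compound 4 is estimated at 50000 nM, within a range of 25000 nM to 100000 nM.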

Compound 4, half-maximal inhibitory concentration: > 50000 nM
Compound 4: a limit, no number (the forecaster's own chance of this, stated with the estimate: 65%); the middle value lies on the limit itself.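

With 2,5-dimethylphenyl on the aromatic nitrogen, compound 4 joins compound 2 and compound 3 in giving only a limit in this assay, so a third aryl group at this position also yields no number. Within the data shown here, the only readable step is an at least 1.3-fold higher number from compound 1 to compound 4 (0.11 log units; that floor lies within the scatter), which gives a floor rather than a size. The steps among compound 2, compound 3 and compound 4 cannot be read, so the loss of the 2-ethyl-6-methylphenyl group's ethyl-bearing pattern in favour of 2,5-dimethylphenyl has no measurable size: the limit of > 50000 nM in this assay, at which 3 of the 4 values shown sit.

On these data alone, how far compound 2, compound 3 and compound 4 lie beyond that limit stays open. Also open, as far as these compounds go, is whether an aryl group carrying an amine or a carboxylic acid at this position, or a longer alkyl chain in place of the aryl group, would give a number in this assay.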